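Swapping a Carbamate Tail for Phenethyl in Compound 1

The compounds below may be only part of what the source reports. "The series", "measured", "known", "first", "only" and "open" are said of these compounds alone.

Compound 1 `COc1ccc(NC(=O)[C@@H]2Cc3ccc(OCC(=O)NO)cc3CN2C(=O)CNC(=O)OC(C)(C)C)cc1` gives 514 nM in an assay on isolated protein for inhibition of histone deacetylase 8 (Homo sapiens), read by fluorescence, with a stated time of 30 min; on this read-out higher numbers stand for weaker inhibition and lower numbers for stronger inhibition.
Compound 2 `COc1ccc(NC(=O)[C@@H]2Cc3ccc(OCC(=O)NO)cc3CN2C(=O)[C@H](CC(C)C)NC(=O)OC(C)(C)C)cc1` gives 163 nM in this assay.

Among the compounds with values here, of the two numbers measured so far, compound 1 has the highest, meaning the weaker inhibition; its only neighbour is compound 2, reached by a 3.2-fold lower number from compound 1 to compound 2 (0.50 log units; beyond the scatter). Compound 3 `COc1ccc(NC(=O)[C@@H]2Cc3ccc(OCC(=O)NO)cc3CN2C(=O)CCCc2ccccc2)cc1` has not yet been measured. It differs from compound 1 by phenethyl in place of (tert-butoxycarbonyl)amino on a saturated chain carbon bound to a carbonyl carbon. Within the data shown here, the one measured step that bears on this change is a 3.2-fold lower number from compound 1 to compound 2 (0.50 log units; beyond the scatter), in which an isobutyl group was added on a saturated chain carbon bound to an amide-type nitrogen and a carbonyl carbon, and the number fell modestly. That step added a group without removing anything, whereas the change to compound 3 removes the carbamate and its donor and acceptors and brings in an aromatic ring, so the comparison is loose. A modest downward step in this assay is expected, probably no larger than that seen for compound 2. Compound 3 is therefore estimated at 250 nM, with a plausible range from 80 nM to 800 nM, a step of a 2.1-fold lower number from compound 1 to compound 3 (0.31 log units; beyond the scatter).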

Compound 3, half-maximal inhibitory concentration: 114 nM
Beside the measured number, compound 3's estimate is 2.2-fold (0.34 log units) above it; the range from low to high includes it.
By their numbers in this assay, from the lowest: compounds 3 and 2 (each within the scatter of the next); then compound 1.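

Both earlier compounds carry the (tert-butoxycarbonyl)amino group, so they could not show whether inhibition depends on it. Compound 3 lacks this group: on the saturated chain carbon bound to a carbonyl carbon it carries phenethyl, which has the same number of heavy atoms but all of them carbon, with a six-membered aromatic ring and no hydrogen-bond donor or acceptor, and the outcome is a 4.5-fold lower number from compound 1 to compound 3 (0.65 log units; beyond the scatter) in this assay rather than a rise. The carbamate, with its hydrogen-bond donor and acceptors, is therefore not required for inhibition at this place, although nothing available here explains why the number moves.

This single swap removes the carbamate and brings in the aromatic ring together, so the compounds shown leave open how much of the step belongs to each change. A cyclohexylethyl group, with a saturated ring in place of the aromatic one, or a free amine at the same place would be needed to pull those two changes apart.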